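The compounds below may be only part of what the source reports. "The series", "measured", "known", "first", "only" and "open" are said of these compounds alone.

The measured compounds and their values in an ADME assay on RAW264.7 cells (Mus musculus) for cytotoxicity, read by MTT assay, with a stated time of 18 h; on this read-out higher numbers stand for lower toxicity in this test and lower numbers for higher toxicity in this test:

- compound 1, `C=C1C(=O)OC[C@H]1CCOC(=O)Nc1ccc(C(=O)OCCCC)cc1`: 8940 nM
- compound 2, `C=C1C(=O)OC[C@@H]1CCOC(=O)Nc1c(C)cccc1C(C)C`: > 50000 nM, a limit of this assay rather than a number
- compound 3, `C=C1C(=O)OC[C@@H]1CCOC(=O)Nc1cc(C(F)(F)F)cc(C(F)(F)F)c1`: 12400 nM

Compound 3 has the highest of the two numbers obtained in this assay, and compound 1 sits nearest to it with a slightly lower number that lies within the scatter, so the two cannot be told apart on this read-out. For compound 2 the result is only a limit of > 50000 nM in this assay, at which 1 of the 3 values shown sits, and gives no number to compare.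

Compound 4 is `C=C1C(=O)OC[C@H]1CCOC(=O)Nc1cc(C(F)(F)F)cc(C(F)(F)F)c1` and has not yet been measured in this assay. How it differs from compound 3:

the two compounds have the same atoms and bonds and differ only in configuration as drawn: 1 of 1 stereo elements differ; a stereocentre at a saturated ring carbon is drawn R in compound 3 and S in compound 4

Since the two compounds share every atom and bond and differ only in configuration as drawn, no measured step among the compounds shown speaks to such a change. The expected step of a 1.0-fold lower number from compound 3 to compound 4 (0.01 log units; within the scatter) is therefore none beyond the scatter in this assay. On that basis compound 4 is expected to give about 12000 nM, with the estimate ranging from 5000 nM to 30000 nM.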

Compound 4, half-maximal cytotoxic concentration: 13900 nM
For compound 4 the middle estimate is 1.2-fold (0.06 log units) below the measured one, within the range that was stated.
By their numbers in this assay, from the lowest: compounds 1, 3 and 4 (each within the scatter of the next). At a limit, above all of these: compound 2.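

In this assay, redrawing the stereocentre at a saturated ring carbon from R to S gives a 1.1-fold higher number from compound 3 to compound 4 (0.05 log units; within the scatter). This pair is the first among the compounds shown that tests configuration alone, and the result can be read without another structural change in the way: the fact that compounds 3 and 4 differ only in the configuration as drawn With the trifluoromethyl groups in place, the read-out therefore resolves no difference between the two drawn configurations at this carbon.

Going by these compounds, whether that holds for other groups on the benzene ring, such as an amine or a carboxylic acid, remains open, since one pair speaks only for its own substituents. The result for compound 2 also adds no number to the comparison, as it is only a limit: the limit of > 50000 nM in this assay, at which 1 of the 4 values shown sits.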